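Methoxy removal in a growth-inhibition series

The source may hold more compounds than are shown below. What is called first, only, known or untested is meant among the compounds shown, and "the series" means these compounds.

Measured compounds:
compound 1, `COc1cc(-c2nc(N)n(CC(=O)Nc3ccc(/C(C)=N\O)cc3)n2)cc(OC)c1OC`, 18%
compound 2, `COc1ccc(-c2nc3sc(-c4ccc(Cl)cc4)cn3n2)cc1`, 25%
compound 3, `COc1cc(-c2nc3sc(-c4ccccc4)cn3n2)cc(OC)c1OC`, 16%

In a functional assay on MDA-MB-435 cells (Homo sapiens) for inhibition, read by sulforhodamine B assay, with a stated time of 48 h, tested at 10 uM (on this read-out lower numbers stand for less inhibition of growth and higher numbers for more inhibition of growth at the one concentration tested), compound 2 gives 25%, the largest of the three numbers. In the same run compound 1 gives 18% and compound 3 gives 16%; both lie within the scatter of compound 2, so the three numbers show no separation. Compound 4, `Clc1ccc(-c2cn3nc(-c4ccccc4)nc3s2)cc1`, differs from compound 2 by hydrogen in place of methoxy on an aromatic carbon. Among the measured compounds shown here, no step between measured compounds covers this change, and the three numbers in hand do not separate, so no step beyond the scatter is expected in this assay in either direction. Compound 4 is expected to give 20%, with a range from 5% to 38%. The expected step is a number 5 percentage points lower from compound 2 to compound 4 (within the scatter).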

Compound 4, percent growth inhibition at one concentration: 11%
Estimate against measurement, compound 4: 9 percentage points above, and the stated range covers the measured number.
By their numbers in this assay, from the lowest: compounds 4, 3, 1 and 2 (each within the scatter of the next, the first and the last beyond it).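

Among the compounds shown here, replacing the methoxy with hydrogen on the aromatic carbon para to a large group gives, in this assay, a number 14 percentage points lower from compound 2 to compound 4 (beyond the scatter), the only step so far and one that clears the scatter. This place on the ring therefore has a readable effect on growth inhibition, though the step is modest and rests on this one pair. No available data explain the step. On these data alone, whether a hydroxy group, an amine or a longer ether chain on this carbon would keep the number of compound 2 remains open. Also open, as far as these compounds go, is whether the same step would appear with other groups elsewhere on the core.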